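Compound 3 to compound 4: replacing the methyl

The compounds below may be only part of what the source reports. "The series", "measured", "known", "first", "only" and "open" are said of these compounds alone.

Of the compounds shown here, three sharing one core have been read so far in a functional assay on HeLa cells (Homo sapiens) for cytotoxicity, read by MTT assay, with a stated time of 72 h; on this read-out higher numbers stand for weaker inhibition and lower numbers for stronger inhibition. Compound 1 `O=C(Nc1nnc(-c2cccc(O)c2O)s1)c1ccc(Cl)cc1` gives 13000 nM, compound 2 `O=C(Nc1nnc(-c2cccc(O)c2O)s1)c1ccccc1` gives 21800 nM, and compound 3 `CC(=O)Nc1nnc(-c2cccc(O)c2O)s1` gives 177000 nM. Compound 3 has the highest number of the three and is the weakest here, with its steps to both others beyond the scatter.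

The next entry is compound 4 `Cc1ccc(C(=O)Nc2nnc(-c3cccc(O)c3O)s2)cc1`, not yet measured. The change from compound 3 is 4-methylphenyl in place of methyl on a carbonyl carbon.

Within the data shown here, two measured steps concern this same place, both running towards methyl. Methyl in place of phenyl gave an 8.1-fold higher number from compound 2 to compound 3 (0.91 log units; beyond the scatter), and methyl in place of 4-chlorophenyl gave a 14-fold higher number from compound 1 to compound 3 (1.13 log units; beyond the scatter). The third step, hydrogen in place of chloro, gave a 1.7-fold higher number from compound 1 to compound 2 (0.22 log units; within the scatter). Among the measured compounds shown here, no measured compound carries the methyl group of 4-methylphenyl, so that detail rests on this single comparison with chloro and hydrogen.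

Going the other way from methyl, a drop of similar size is expected in this assay. The estimated step is a 10-fold lower number from compound 3 to compound 4 (1.02 log units; beyond the scatter). Compound 4 is expected at 17000 nM, with an estimated range of 8000 nM to 36000 nM.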

Compound 4, half-maximal inhibitory concentration: 13400 nM
For compound 4 the middle estimate is 1.3-fold (0.10 log units) above the measured one; measured number inside the range.
By their numbers in this assay, from the lowest: compounds 1, 4 and 2 (each within the scatter of the next); then compound 3.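

Replacing methyl on the carbonyl carbon with an aromatic ring now has a third example in this assay: 4-methylphenyl gives a 13-fold lower number from compound 3 to compound 4 (1.12 log units; beyond the scatter), so the gain over methyl, earlier seen only with phenyl and 4-chlorophenyl, holds for all three aromatic groups shown. The group on the aromatic carbon does not separate these compounds: methyl in place of hydrogen gives a 1.6-fold lower number from compound 2 to compound 4 (0.21 log units; within the scatter), and methyl in place of chloro gives a 1.0-fold higher number from compound 1 to compound 4 (0.01 log units; within the scatter), both within the scatter, so hydrogen, chloro and methyl cannot be ranked at this place. The large change in this series therefore goes with having an aromatic ring rather than methyl on the carbonyl carbon, not with what that ring carries, and no supporting measurement explains the step.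

An amine, a carboxylic acid or a methoxy group on the same aromatic carbon would test whether this flat response extends beyond hydrogen, chloro and methyl. A longer alkyl chain such as butyl on the carbonyl carbon would show whether an aromatic ring is needed for the gain over methyl or whether a non-aromatic group can match it.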